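Swapping 3-chlorophenyl for 5-bromopyridin-3-yl

The source may hold more compounds than are shown below. What is called first, only, known or untested is meant among the compounds shown, and "the series" means these compounds.

- compound 1 `Nc1ccccc1NC(=O)c1ccc(NC(=S)NCc2ccc(Cl)nc2)cc1`: 19000 nM
- compound 2 `Nc1ccccc1NC(=O)c1ccc(NC(=S)NCc2cccnc2)cc1`: 4200 nM
- compound 3 `Nc1ccccc1NC(=O)c1ccc(NC(=S)NCc2cccc(Cl)c2)cc1`: 2600 nM

These values come from a functional assay on HepG2 cells (Homo sapiens) for cytotoxicity, read by MTT assay, with a stated time of 72 h; on this read-out lower numbers stand for stronger inhibition and higher numbers for weaker inhibition. Compound 3 stands at 2600 nM, well clear of compound 1 but not separable from compound 2, as the measured step shows: a 1.6-fold lower number from compound 2 to compound 3 (0.21 log units; within the scatter).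

The unmeasured compound 4 `Nc1ccccc1NC(=O)c1ccc(NC(=S)NCc2cncc(Br)c2)cc1` carries 5-bromopyridin-3-yl in place of 3-chlorophenyl on a saturated chain carbon bound to an amide-type nitrogen.

The step above, between 3-chlorophenyl and pyridin-3-yl, is the closest guide, and it stayed small. Two modest steps lead away from 6-chloropyridin-3-yl: a 4.5-fold lower number from compound 1 to compound 2 (0.66 log units; beyond the scatter) and a 7.3-fold lower number from compound 1 to compound 3 (0.86 log units; beyond the scatter). Within the data shown here, they warn that a halogen on the pyridine can raise the number, but no bromo compound has been measured, and the halogen's place differs. A small upward step is therefore expected, perhaps none beyond the scatter, with a wide margin on the high side.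

The estimated outcome is a 1.7-fold higher number from compound 3 to compound 4 (0.24 log units; within the scatter).

The expected value for compound 4 is 4500 nM, with an estimated range of 1800 nM to 13000 nM.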

Compound 4, half-maximal inhibitory concentration: 7500 nM
Compound 4: the middle estimate sits 1.7-fold (0.22 log units) below what was measured; low and high end bracket the measured number.
By their numbers in this assay, from the lowest: compounds 3, 2 and 4 (each within the scatter of the next, the first and the last beyond it); then compound 1.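

In this assay, a pyridine ring carrying a halogen does not match 3-chlorophenyl at this position, as the swap shows (a 2.9-fold higher number from compound 3 to compound 4 (0.46 log units; beyond the scatter)). Bromo on the pyridine of compound 2 gives no separable change (a 1.8-fold higher number from compound 2 to compound 4 (0.25 log units; within the scatter)), and the two halogen-bearing pyridines do separate (a 2.5-fold lower number from compound 1 to compound 4 (0.40 log units; beyond the scatter)), so a halogen on this ring does not always bring the high number of compound 1. Nothing in the available data explains these differences.

Compound 1 and compound 4 differ in both the halogen and its place on the ring, so the data cannot show which of the two matters. Also open, as far as these compounds go, is how an amine or a carboxylic acid on this ring would read, or a longer chain carrying it.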